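A few compounds are considered here, and "the series" means these few. Any claim that something is new, unique, unknown or untested is made for them only; others in the source may bear on it.

Compound 1 `NC(=O)c1c(NC(=O)c2ccco2)sc2c1CCCC2`: 1500 nM
Compound 2 `Cc1ccc(C(=O)Nc2sc3c(c2C(N)=O)CCCC3)cc1`: 450 nM
Compound 3 `Cc1cccc(C(=O)Nc2sc3c(c2C(N)=O)CCCC3)c1`: 3200 nM
Compound 4 `Cc1ccc(C(=O)Nc2sc3c(c2C(N)=O)CCCC3)cc1C`: not yet measured

All of these values come from a functional assay on MV4-11 cells (Homo sapiens) for antiproliferative activity; on this read-out lower numbers stand for stronger inhibition and higher numbers for weaker inhibition. Compound 3, at 3200 nM, has the highest number of the three and is the weakest so far. Its neighbours are not far off on one side: the result is a 2.1-fold higher number from compound 1 to compound 3 (0.33 log units; beyond the scatter), with a 3-methylphenyl in place of furan-2-yl.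

The change now followed is methyl in place of hydrogen on an aromatic carbon. Compound 4 therefore carries both the methyl of compound 3 and, para to a large group, the methyl that compound 2 carries on its 4-methylphenyl.

The most relevant measured step is a 7.1-fold higher number from compound 2 to compound 3 (0.85 log units; beyond the scatter), and a 3.3-fold lower number from compound 1 to compound 2 (0.52 log units; beyond the scatter) shows the same 4-methylphenyl giving the lowest number. Among the measured compounds shown here, no measured compound shows the two methyl groups together, so the data do not tell whether the gain of compound 2 survives with the second methyl present. A modest drop in this assay is therefore expected, probably only part of the gap between compound 3 and compound 2.

The expected step is a 3.2-fold lower number from compound 3 to compound 4 (0.51 log units; beyond the scatter). For compound 4 the estimate is 1000 nM, with an expected range from 300 nM to 3000 nM.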

Compound 4, half-maximal inhibitory concentration: 710 nM
Compound 4: middle estimate off by 1.4-fold (0.15 log units), on the high side, and the stated range covers the measured number.
By their numbers in this assay, from the lowest: compounds 2 and 4 (each within the scatter of the next); then compound 1; then compound 3.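

In this assay, among the compounds shown here, adding a methyl para to a large group and ortho to a methyl group on the ring of compound 3 gives a 4.5-fold lower number from compound 3 to compound 4 (0.65 log units; beyond the scatter), so the low number that goes with the methyl of compound 2 largely holds with a second methyl present, which the earlier compounds could not show. Read from the other side, the same kind of change gives a 1.6-fold higher number from compound 2 to compound 4 (0.20 log units; within the scatter), and this step lies within the scatter, so compound 2 and compound 4 cannot be ranked against each other. The same added methyl thus counts for much on the ring of compound 3 and for no readable difference on the ring of compound 2, and nothing at hand explains this contrast.

The compounds shown leave open whether this place accepts anything other than methyl, such as a methoxy group, a chlorine atom or an amine. They also leave open how far the pattern carries to the rest of the molecule, for instance with a nitrile or a carboxylic acid in place of the primary amide on the shared core.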